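The source may report more compounds than this note shows. Statements on the series, on what has been measured and on what is new or still open speak of the compounds shown alone.

Compound 3 `COc1ccc2[nH]c(C(=O)N3CC(=O)N(Cc4ccccc4)[C@@H](COC(C)(C)C)C3)cc2c1` stands highest of the two numbers reported in an ADME assay on Vero cells (Chlorocebus sabaeus) for cytotoxicity, with a stated time of 7 days (on this read-out lower numbers stand for higher toxicity in this test and higher numbers for lower toxicity in this test), where compound 3 gives 78200 nM. Its nearest neighbour is compound 1 `COc1ccc2[nH]c(C(=O)N3CC(=O)N(Cc4ccccc4)[C@@H](CN4CCC5(CC4)CC5)C3)cc2c1`; in this assay compound 1 gives 17100 nM, the step being a 4.6-fold higher number from compound 1 to compound 3 (0.66 log units; beyond the scatter). Compound 2 `COc1ccc2[nH]c(C(=O)N3CC(=O)N(Cc4ccccc4)[C@@H](CN4CCC(C)CC4)C3)cc2c1` reaches only a limit in this assay, namely > 30000 nM. The step of an at least 1.7-fold higher number from compound 1 to compound 2 (0.24 log units; that floor lies within the scatter) and the step that the limit leaves unreadable from compound 2 to compound 3 tell little. Compound 4 `COc1ccc2[nH]c(C(=O)N3CC(=O)N(Cc4ccccc4)[C@@H](N4CCc5ccccc54)C3)cc2c1` differs from compound 3 by 2,3-dihydro-1H-indol-1-yl in place of (tert-butoxy)methyl on a saturated ring carbon. None of the measured steps concerns a change of this kind, so they set no firm direction; compound 3 holds the highest number shown, which leaves more room downward than upward. Compound 4 is therefore expected to give about 30000 nM in this assay, between 10000 nM and 90000 nM. For compound 4 this estimate means an expected 2.6-fold lower number from compound 3 to compound 4 (0.42 log units; beyond the scatter).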

Compound 4, half-maximal cytotoxic concentration: > 100000 nM
Compound 4 ended at the assay's limit (the forecaster's own chance of this, stated with the estimate: 30%); middle value at least 3.3-fold (0.52 log units) away from the limit.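

In this assay compound 4 reaches only a limit and gives no number: the limit of > 100000 nM in this assay, at which 1 of the 4 values shown sits. At this saturated ring carbon, 2,3-dihydro-1H-indol-1-yl brings the read-out to no lower number than the earlier side chains, with an at least 1.2-fold higher number from compound 3 to compound 4 (0.10 log units; that floor lies within the scatter) and, more clearly, an at least 5.8-fold higher number from compound 1 to compound 4 (0.76 log units; beyond the scatter). The step involving compound 2 cannot be read.

Going by these compounds, the true value of compound 4 stays open, so its order relative to compound 3 remains unsettled. Also open, on these data alone, is whether piperidin-1-yl or a carboxylic acid on this carbon would give a similar read-out.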